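A few compounds are considered here, and "the series" means these few. Any claim that something is new, unique, unknown or untested is made for them only; others in the source may bear on it.

Among the measured compounds shown here, compound 3 `O=c1c(Cl)c(CSC(=S)N2CCCC2)oc2ccccc12` gives 600 nM in a functional assay on HEp-2 cells (Homo sapiens) for antiproliferative activity, read by MTT assay, with a stated time of 72 h (a lower number here means a stronger inhibitor, a higher number a weaker inhibitor), the lowest of the three numbers so far. For the measured compounds named here, compound 2 `O=c1cc(CSC(=S)N2CCCCC2)oc2cc(Cl)ccc12` gives 1600 nM in this assay, and compound 1 `O=c1c(Cl)c(CSC(=S)N2CCOCC2)oc2ccccc12` gives 9000 nM; the only single-point step among them is a 15-fold lower number from compound 1 to compound 3 (1.18 log units; beyond the scatter), a change at the thiocarbonyl carbon. Compound 4 `O=c1cc(CSC(=S)N2CCCC2)oc2ccccc12` differs from compound 3 in one place: hydrogen in place of chloro on an aromatic carbon. Going by the values given here, no measured step touches a change at that aromatic carbon; compound 2 also lacks a chloro there, but it differs from compound 3 elsewhere as well, so its value bears only loosely. With the thiocarbonyl substituent held constant, the step of a 2.0-fold higher number from compound 3 to compound 4 (0.30 log units; within the scatter) is expected to be modest and toward a higher number, with wide uncertainty. Compound 4 is therefore estimated at 1200 nM, within 400 nM to 4000 nM.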

Compound 4, half-maximal inhibitory concentration: 9100 nM
The estimate for compound 4 lay 7.6-fold (0.88 log units) below the measured number; the measured number lies above the stated range.
By their numbers in this assay, from the lowest: compound 3; then compound 2; then compounds 1 and 4 (each within the scatter of the next).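

In this assay, the chloro on this aromatic carbon, two atoms from the ring oxygen, proves to matter: with pyrrolidin-1-yl held constant, hydrogen in its place gives a 15-fold higher number from compound 3 to compound 4 (1.18 log units; beyond the scatter). This single-atom change at the aromatic carbon matches in size the earlier change at the thiocarbonyl carbon, a 15-fold lower number from compound 1 to compound 3 (1.18 log units; beyond the scatter). Nothing available here accounts for the size of this step.

From the compounds shown here alone, whether chloro has the same influence alongside morpholin-4-yl remains open. So does whether fluoro, bromo or methyl on this carbon would match chloro.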